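Working notes: the step from compound 3 to compound 4

The source may report more compounds than this note shows. Statements on the series, on what has been measured and on what is new or still open speak of the compounds shown alone.

Values in a functional assay on HCT-116 cells (Homo sapiens) for inhibition, read by MTT assay, with a stated time of 48 h; on this read-out lower numbers stand for stronger inhibition and higher numbers for weaker inhibition
- compound 1 `C/C=C/C(=O)N(Cc1ccc(OC)c(Br)c1)c1cc(OC)c(OC)c(OC)c1` gives 2800 nM
- compound 2 `COc1ccc(CNc2cc(OC)c(OC)c(OC)c2)cc1F` gives 32200 nM
- compound 3 `C/C=C/C(=O)N(Cc1cccc(O)c1)c1cc(OC)c(OC)c(OC)c1` gives 6700 nM

Compound 3 has the second highest of the three numbers and lies closer to compound 1 than to compound 2. Next is compound 4 `C/C=C/C(=O)N(Cc1ccc(OC)c(F)c1)c1cc(OC)c(OC)c(OC)c1`, with 3-fluoro-4-methoxyphenyl in place of 3-hydroxyphenyl on a saturated chain carbon bound to an amide-type nitrogen. For the measured compounds named here, one measured step bears directly on this change, and it is modest and beyond the scatter: a 2.4-fold higher number from compound 1 to compound 3 (0.38 log units; beyond the scatter). Compound 1 carries 3-bromo-4-methoxyphenyl, which differs from the entering group in its halogen, so that step read in reverse points to a lower number in this assay. Compound 2 also carries 3-fluoro-4-methoxyphenyl but is no amide, and it gives 32200 nM, so it says little about this step. A modest step is expected, and the estimated step is a 2.1-fold lower number from compound 3 to compound 4 (0.32 log units; beyond the scatter). The estimate for compound 4 is 3200 nM, with an expected range from 1100 nM to 9500 nM.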

Compound 4, half-maximal inhibitory concentration: 1160 nM
For compound 4 the middle estimate is 2.8-fold (0.44 log units) above the measured one; the range from low to high includes it.
By their numbers in this assay, from the lowest: compound 4; then compound 1; then compound 3; then compound 2.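

In this assay, the full change of 3-hydroxyphenyl to 3-fluoro-4-methoxyphenyl on a saturated chain carbon bound to an amide-type nitrogen gives a 5.8-fold lower number from compound 3 to compound 4 (0.76 log units; beyond the scatter). The halogen alone also counts here: fluoro in place of bromo on an aromatic carbon gives a 2.4-fold lower number from compound 1 to compound 4 (0.38 log units; beyond the scatter), so the two halogens are not interchangeable in this series. The largest step yet comes from the nitrogen rather than the ring, with (prop-1-en-1-yl)carbonyl in place of hydrogen giving a 28-fold lower number from compound 2 to compound 4 (1.44 log units; beyond the scatter).

No measurement at hand explains these steps. The compounds shown do not separate the share of the fluoro from that of the methoxy in the change from compound 3, and they leave open how chloro on the aromatic carbon, or a longer chain on the carbonyl, would compare.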